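Changing the aryl group on the aromatic nitrogen

A few compounds are considered here, and "the series" means these few. Any claim that something is new, unique, unknown or untested is made for them only; others in the source may bear on it.

Measured so far in a functional assay on HCT-116 cells (Homo sapiens) for antiproliferative activity, read by MTT assay, with a stated time of 48 h; a lower number here means a stronger inhibitor, a higher number a weaker inhibitor:
compound 1 `N#CC1=C(N)Oc2c(N)cc3nc4ccccc4nc3c2C12C(=O)N(Cc1cnnn1-c1cccc(Br)c1)c1ccccc12` — 26100 nM
compound 2 `Cc1ccc(-n2nncc2CN2C(=O)C3(C(C#N)=C(N)Oc4c(N)cc5nc6ccccc6nc5c43)c3ccccc32)cc1C` — a limit of the assay, > 50000 nM
compound 3 `CCc1cccc(CC)c1-n1nncc1CN1C(=O)C2(C(C#N)=C(N)Oc3c(N)cc4nc5ccccc5nc4c32)c2ccccc21` — 37600 nM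

Compound 3 gives the highest of the two numbers shown, and compound 1 lies within the scatter of it, as a 1.4-fold higher number from compound 1 to compound 3 (0.16 log units; within the scatter) shows. For compound 2 only a limit is known (the limit of > 50000 nM in this assay, at which 1 of the 3 values shown sits). Compound 4 `N#CC1=C(N)Oc2c(N)cc3nc4ccccc4nc3c2C12C(=O)N(Cc1cnnn1-c1ccc(Cl)cc1[N+](=O)[O-])c1ccccc12` differs from compound 3 only in the aryl group: 4-chloro-2-nitrophenyl in place of 2,6-diethylphenyl on an aromatic nitrogen. The comparable steps, a 1.4-fold higher number from compound 1 to compound 3 (0.16 log units; within the scatter) and an at least 1.9-fold higher number from compound 1 to compound 2 (0.28 log units; that floor lies within the scatter), stay within the scatter, so no step beyond the scatter is expected in this assay for compound 4, whose estimated value is 32000 nM (range 12000 nM to 60000 nM), a step of a 1.2-fold lower number from compound 3 to compound 4 (0.07 log units; within the scatter) that is expected to fall within the usual scatter.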

Compound 4, half-maximal inhibitory concentration: 28700 nM
Estimate against measurement, compound 4: 1.1-fold (0.05 log units) above; measured number inside the range.
By their numbers in this assay, from the lowest: compounds 1, 4 and 3 (each within the scatter of the next). At a limit, above all of these: compound 2.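

The 4-chloro-2-nitrophenyl group brings hydrogen-bond acceptors to this position, where 2,6-diethylphenyl has none, yet the steps stay within the scatter: a 1.3-fold lower number from compound 3 to compound 4 (0.12 log units; within the scatter), and a 1.1-fold higher number from compound 1 to compound 4 (0.04 log units; within the scatter). The third step, an at least 1.7-fold lower number from compound 2 to compound 4 (0.24 log units; that floor lies within the scatter), also shows nothing beyond the scatter. Compound 2 is known only as a limit of the assay: the limit of > 50000 nM in this assay, at which 1 of the 4 values shown sits.

As far as these compounds go, all four groups on this nitrogen are substituted phenyl rings, so the effect of an amine, a carboxylic acid or a longer alkyl chain here remains open. From the compounds shown here alone, whether any group at this position can move the number beyond the scatter also remains open.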